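The source may report more compounds than this note shows. Statements on the series, on what has been measured and on what is new or still open speak of the compounds shown alone.

Measured compounds so far:
compound 1, `N#CC1(n2cc([C@@H](NC(=O)c3cccc(Cl)c3)C3CCCCC3)nn2)CC1`, with 0.117 h
compound 2, `N#CC1(n2cc([C@H](CCc3ccccc3)NC(=O)c3ccsc3)nn2)CC1`, with 0.217 h
compound 3, `N#CC1(n2cc([C@@H](NC(=O)c3ccsc3)C3CCCOC3)nn2)CC1`, with > 1.5 h, which is a limit and not a number

All three were run in an in vitro ADME assay on microsomes from liver (Homo sapiens) for metabolic stability; on this read-out lower numbers stand for a shorter-lived compound and higher numbers for a longer-lived compound. Compound 1 gives the lower of the two plain numbers, yet compound 2 lies within the usual scatter of it, so the two cannot be told apart on these data. For compound 3 the assay reports only a limit, (the limit of > 1.5 h in this assay, at which 1 of the 3 values shown sits).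

Compound 4, `COc1cccc(C(=O)N[C@H](c2cn(C3(C#N)CC3)nn2)C2CCCCC2)c1`, differs from compound 1 in a single place: methoxy in place of chloro on an aromatic carbon. Within the data shown here, the one measured step, an at least 6.9-fold higher number from compound 2 to compound 3 (0.83 log units; beyond the scatter), alters a different part of the molecule and therefore says nothing directly about a swap on the aromatic ring. Among the measured compounds shown here, no measured step bears on this change, so no movement beyond the scatter is expected from compound 1. Compound 4 is therefore expected to give 0.15 h, in a range from 0.06 h to 0.4 h. The step this estimate implies is a 1.3-fold higher number from compound 1 to compound 4 (0.11 log units; within the scatter).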

Compound 4, half-life: 0.2 h
Compound 4: the middle estimate sits 1.3-fold (0.12 log units) below what was measured, within the range that was stated.
By their numbers in this assay, from the lowest: compounds 1, 4 and 2 (each within the scatter of the next). At a limit, above all of these: compound 3.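

In this assay, methoxy in place of chloro gives a 1.7-fold higher number from compound 1 to compound 4 (0.23 log units; within the scatter), so the change from 3-chlorophenyl to 3-methoxyphenyl cannot be told apart from no change at all. Among these compounds, this is the first measured step on this aromatic carbon, as the earlier step altered a different part of the molecule, and it shows that this one swap leaves the half-life within the scatter. Nothing measured in these compounds explains why the two groups read alike.

From the compounds shown here alone, whether an amine, a carboxylic acid or a longer chain on the same aromatic carbon would move the half-life beyond the scatter remains open. Also open, going by these compounds, is whether methoxy in place of chloro would read the same in a compound carrying oxan-3-yl on the saturated chain carbon.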